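Urea aryl swap on a shared core: from compound 3 to 4

A few compounds are considered here, and "the series" means these few. Any claim that something is new, unique, unknown or untested is made for them only; others in the source may bear on it.

Measured compounds:
compound 1 `Cc1c(Cc2ccccc2)c(NNC(=O)Nc2cc(Cl)nc(Cl)c2)nc2c1cnn2C`: 870 nM
compound 2 `CCCc1cc(NNC(=O)Nc2cc(Cl)nc(Cl)c2)nc2c1c(C)nn2C`: 2360 nM
compound 3 `Cn1ncc2c(-c3ccc(F)cc3)cc(NNC(=O)Nc3cc(Cl)cc(Cl)c3)nc21`: 4980 nM

In an assay on isolated protein for binding affinity to sphingosine 1-phosphate receptor 2 (Homo sapiens), read by surface plasmon resonance (a higher number here means weaker binding, a lower number tighter binding), compound 1 gives 870 nM. Compound 2 gives 2360 nM in this assay. Compound 3 gives 4980 nM in this assay, the highest of the three numbers, with compound 2 nearest and compound 1 furthest, both gaps beyond the scatter. For the measured compounds named here, all three share a urea linkage; compound 3 carries a 3,5-dichlorophenyl on the amide-type nitrogen, while compounds 1 and 2 carry a chloropyridinyl there, and each also has a different core, so no single-change step among them is available.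

Compound 4 `Cn1ncc2c(-c3ccc(F)cc3)cc(NNC(=O)Nc3cc(Cl)nc(OCCF)c3)nc21` differs from compound 3 in one place: 2-chloro-6-(2-fluoroethoxy)pyridin-4-yl in place of 3,5-dichlorophenyl on an amide-type nitrogen. Going by the values given here, no measured pair isolates this change. Since compounds 1 and 2, which both carry a pyridinyl urea, give lower numbers than compound 3, a modest step toward tighter binding is expected for compound 4, as a 2.0-fold lower number from compound 3 to compound 4 (0.30 log units; within the scatter), though the differing cores leave it uncertain. Compound 4 is therefore estimated at 2500 nM in this assay, within a range of 800 nM to 8000 nM.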

Compound 4, dissociation constant: 2790 nM
Estimate against measurement, compound 4: 1.1-fold (0.05 log units) below; low and high end bracket the measured number.
By their numbers in this assay, from the lowest: compound 1; then compounds 2, 4 and 3 (each within the scatter of the next, the first and the last beyond it).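

For the compounds shown here, this is the first single-change reading at this position: on the shared core, this assay gives a 1.8-fold lower number from compound 3 to compound 4 (0.25 log units; within the scatter) when 2-chloro-6-(2-fluoroethoxy)pyridin-4-yl replaces 3,5-dichlorophenyl on the amide-type nitrogen. The change brings a larger group with a hetero atom in the ring and hydrogen-bond acceptors that the 3,5-dichlorophenyl lacks, yet the two compounds cannot be told apart in this assay. Nothing given here bears on why the change reads this way.

The ring nitrogen and the 2-fluoroethoxy chain enter together in this one step, and the compounds shown do not separate their shares. Also open, on these data alone, is whether a methoxy group, a morpholine or a longer chain in place of the 2-fluoroethoxy chain would give a step beyond the scatter on this core.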